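The source may report more compounds than this note shows. Statements on the series, on what has been measured and on what is new or still open speak of the compounds shown alone.

The measured compounds:
compound 1 `N/N=C1\C(=O)Nc2ccc(S(=O)(=O)N3CCOCC3)cc21` gives 391000 nM in an ADME assay on WI-38 cells (Homo sapiens) for cytotoxicity, read by sulforhodamine B assay, with a stated time of 24 h; a higher number here means a weaker inhibitor, a lower number a stronger inhibitor
compound 2 `O=C1Nc2ccc(S(=O)(=O)N3CCOCC3)cc2/C1=N/c1cccc(C(F)(F)F)c1` gives 226000 nM
compound 3 `O=C1Nc2ccc(S(=O)(=O)N3CCOCC3)cc2/C1=N/c1ccc(C(=O)O)cc1` gives 313000 nM

Compound 1 has the highest of the three numbers, but its steps to the other two, a 1.7-fold lower number from compound 1 to compound 2 (0.24 log units; within the scatter) and a 1.2-fold lower number from compound 1 to compound 3 (0.10 log units; within the scatter), both lie within the scatter, so the three compounds cannot be put in any order. Compound 4 `O=C1Nc2ccc(S(=O)(=O)N3CCOCC3)cc2/C1=N/c1ccc(Cl)cc1` differs from compound 1 in one place: 4-chlorophenyl in place of amino on a double-bonded nitrogen. Among the compounds with values here, two measured steps bear on this change, since in each of them the amino on the double-bonded nitrogen also gives way to a substituted phenyl: a 1.7-fold lower number from compound 1 to compound 2 (0.24 log units; within the scatter) and a 1.2-fold lower number from compound 1 to compound 3 (0.10 log units; within the scatter). Neither moved the number beyond the scatter, and the further step a 1.4-fold higher number from compound 2 to compound 3 (0.14 log units; within the scatter) was also within it. A step of no more than the scatter is therefore expected from compound 1 to compound 4, namely a 1.4-fold lower number from compound 1 to compound 4 (0.15 log units; within the scatter), leaning toward a slightly lower number. Compound 4 is estimated at 280000 nM, within a range from 140000 nM to 560000 nM.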

Compound 4, half-maximal inhibitory concentration: 468000 nM
For compound 4 the middle estimate is 1.7-fold (0.22 log units) below the measured one, and the stated range covers the measured number.
By their numbers in this assay, from the lowest: compounds 2, 3, 1 and 4 (each within the scatter of the next, the first and the last beyond it).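

In this assay, a 1.2-fold higher number from compound 1 to compound 4 (0.08 log units; within the scatter), so a third substituted phenyl on the double-bonded nitrogen stays within the scatter of the amino group. Exchanging the substituent on the phenyl ring also stays within it, with chloro in place of carboxy giving a 1.5-fold higher number from compound 3 to compound 4 (0.17 log units; within the scatter). Within the data shown here, the new information is a 2.1-fold higher number from compound 2 to compound 4 (0.32 log units; beyond the scatter), the first step in this set to pass the scatter, and only a modest one, so the substituted phenyl groups at this position are not all interchangeable in this assay, though the two ends of the series are only just separated.

Nothing available here gives a reason for that small gap. Still open, from the compounds shown here alone, is whether an amine or a longer carbon chain on the double-bonded nitrogen, in place of these phenyl groups, would stay within the same narrow band of numbers.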